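Working notes: amide nitrogen substituent versus cytotoxicity

A few compounds are considered here, and "the series" means these few. Any claim that something is new, unique, unknown or untested is made for them only; others in the source may bear on it.

Measured so far:
compound 1 `Cc1cccc(NC(=O)c2cccc(/C=C3\CC(=O)N(c4ccccc4)C3=O)c2)c1` — > 100000 nM
compound 2 `COc1ccc(NC(=O)c2cccc(/C=C3\CC(=O)N(c4ccc(C)cc4)C3=O)c2)cc1` — > 100000 nM

In an ADME assay on NCM460 cells (Homo sapiens) for cytotoxicity, read by MTT assay, with a stated time of 72 h (on this read-out lower numbers stand for stronger inhibition and higher numbers for weaker inhibition), compound 1 gives > 100000 nM, which is a limit of the assay and not a number. Compound 2 in this assay gives > 100000 nM, again a limit rather than a measured number. For the measured compounds named here, compound 1 therefore cannot be placed against compound 2 on these figures: both values sit at the limit of > 100000 nM in this assay, at which 2 of the 2 values shown sit, and no step between measured compounds exists that would show how a change at the amide nitrogen moves this read-out.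

Compound 3 `O=C(NCC1CCCCC1)c1cccc(/C=C2\CC(=O)N(c3ccccc3)C2=O)c1` differs from compound 1 in one place: cyclohexylmethyl in place of 3-methylphenyl on an amide-type nitrogen. Going by the values given here, with no measured step on this change and both known values resting at the limit, the step from compound 1 to compound 3 in this assay is expected to be none beyond the scatter, as a number no higher from compound 1 to compound 3 (the limit leaves the size open) states. Compound 3 is accordingly expected to give about 100000 nM in this assay, within 30000 nM to 300000 nM, and most probably to return a limit once more rather than a numerical value.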

Compound 3, half-maximal inhibitory concentration: > 100000 nM
Compound 3 was reported as a limit; the forecaster's own chance of this, stated with the estimate: 75%; the middle value lies on the limit itself.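

In this assay compound 3 gives > 100000 nM as a limit of the assay and not a number. No step from compound 1 to compound 3 can be read, both compounds resting at a limit: the limit of > 100000 nM in this assay, at which 3 of the 3 values shown sit.

Still open, as far as these compounds go, is whether any change on the amide-type nitrogen brings a numerical value in this assay at all.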